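This account rests on a few compounds, and the source may have more. Where it says the series, first, only, none or still open, it means among the compounds named here.

Measured compounds:
compound 1 `Cc1cccc(-c2nc3cc(C)ccc3c(=O)[nH]2)c1` — 56.3%
compound 2 `Cc1ccc2nc(-c3cccc4ccccc34)[nH]c(=O)c2c1` — "not determined" (no result reported)
compound 3 `Cc1ccc2nc(-c3cccc(C(F)(F)F)c3)[nH]c(=O)c2c1` — 4.2%

Three compounds sharing one core have been run in an assay on isolated protein for inhibition of DNA topoisomerase 1 (Homo sapiens), with a stated time of 30 min, tested at 20 uM; a higher number here means a stronger effect of the compound at the concentration tested, a lower number a weaker effect. Compound 1 gives 56.3% in this assay, the highest of the two numbers available. Compound 3, the nearest of the others, gives 4.2%, a figure far below that of compound 1 and well beyond the scatter of the method. For compound 2 the result in this assay is "not determined" (no result reported), so no number can be set against it. For the measured compounds named here, with only two numbers, no step between measured compounds that differ in one place can be drawn, and nothing can be said of a trend across the set.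

The next compound, compound 4 `COc1cccc(-c2nc3cc(C)ccc3c(=O)[nH]2)c1`, is derived from compound 1 by a single change: methoxy in place of methyl on an aromatic carbon. Going by the values given here, the two numbers in hand do not tell how this assay answers to a change at this position of the ring, since the one comparison available, between compound 1 and compound 3, concerns a different group. A step of moderate size is expected in this assay, most likely downward from compound 1, though a step of no more than the scatter cannot be ruled out. Compound 4 is therefore estimated at 40%, with a range from 12% to 68%, which corresponds to an expected step of a number 16.3 percentage points lower from compound 1 to compound 4 (beyond the scatter).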

Compound 4, a percentage reported as inhibition, at one concentration (the size of the read-out at that concentration, not a potency): 80%
Beside the measured number, compound 4's estimate is 40 percentage points below it; measured number above the stated range.
By their numbers in this assay, from the lowest: compound 3; then compound 1; then compound 4.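

In this assay this ring position now has its first directly readable step: methoxy in place of methyl on an aromatic carbon, meta to a large group, gives a number 23.7 percentage points higher from compound 1 to compound 4 (beyond the scatter). Methyl is thus not the limit at this place, since the entering group brings an oxygen and a hydrogen-bond acceptor that methyl lacks, and the read-out rises rather than falls; this is one step on one pair, not yet a trend for the series. No measurement at hand bears on the cause of this step.

Still open, going by these compounds, is whether the rise goes with the oxygen itself or simply with a longer group at this place: a hydroxyl, an ethoxy and an ethyl on the same aromatic carbon would pull those readings apart. Also open is how far the position extends, as an amine, a carboxylic acid or a longer alkoxy chain here could show whether the read-out in this assay keeps climbing or turns back, and a read-out at a single concentration gives no potency for any of these compounds.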